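From hydroxy to chloro on the aromatic ring

The compounds below may be only part of what the source reports. "The series", "measured", "known", "first", "only" and "open" are said of these compounds alone.

Measured in a functional assay on the whole organism (Hindlimb, strain albino) with Mus musculus as the target, in the maximal electroshock model, with a stated time of 0.5 h (a higher number here means that more compound is needed for the effect, a lower number that less compound is needed), so far:
Compound 1 `Cc1ccc2nc(NC(=O)/C=C/OC3=CC=C3)sc2c1` gives 505 umol/kg
Compound 2 `O=C(/C=C/c1ccc(Cl)cc1)Nc1nc2ccc(Cl)cc2s1` gives 204 umol/kg
Compound 3 `Cc1ccc2nc(NC(=O)/C=C/c3ccc(O)cc3)sc2c1` gives 271 umol/kg

The value of compound 3 lies within the usual scatter of both other compounds. Compound 4 `Cc1ccc2nc(NC(=O)/C=C/c3ccc(Cl)cc3)sc2c1`, not yet measured, carries chloro in place of hydroxy on an aromatic carbon, para to a large group (chloro in place of hydroxy on an aromatic carbon). Going by the values given here, the one measured step, a 1.9-fold lower number from compound 1 to compound 3 (0.27 log units; within the scatter), changes a different group and bears only loosely. Compound 2 also holds the 4-chlorophenyl group, differs elsewhere too, and gives 204 umol/kg, within the scatter of compound 3. No step beyond the scatter is therefore expected in this assay. The expected step is a 1.2-fold lower number from compound 3 to compound 4 (0.07 log units; within the scatter). Compound 4 is estimated at 230 umol/kg, with an expected range from 110 umol/kg to 480 umol/kg.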

Compound 4, dose for half-maximal effect: 152 umol/kg
Compound 4: the middle estimate sits 1.5-fold (0.18 log units) above what was measured, within the range that was stated.
By their numbers in this assay, from the lowest: compounds 4, 2, 3 and 1 (each within the scatter of the next, the first and the last beyond it).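

In this assay, chloro in place of hydroxy on the aromatic carbon gives no step beyond the scatter (a 1.8-fold lower number from compound 3 to compound 4 (0.25 log units; within the scatter)). Methyl in place of chloro on an aromatic carbon elsewhere in the molecule also stays within it (a 1.3-fold lower number from compound 2 to compound 4 (0.13 log units; within the scatter)). Only with the 4-chlorophenyl group does replacing the group of compound 1 give a step beyond the scatter (a 3.3-fold lower number from compound 1 to compound 4 (0.52 log units; beyond the scatter)), whereas with the 4-hydroxyphenyl group it does not (a 1.9-fold lower number from compound 1 to compound 3 (0.27 log units; within the scatter)).

From the compounds shown here alone, whether an amine or a methoxy group at this position would differ from chloro remains open. No measurement at hand accounts for these values.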